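Sulfamoylurea series: acyclic amines on the sulfonyl sulfur

The source may hold more compounds than are shown below. What is called first, only, known or untested is meant among the compounds shown, and "the series" means these compounds.

Measured compounds:
compound 1 `CC(C)c1cccc(C(C)C)c1NC(=O)NS(=O)(=O)N(C)C` gives 3900 nM in an assay on liver for inhibition of sterol O-acyltransferase 1 (Rattus norvegicus), using microsomes; on this read-out higher numbers stand for weaker inhibition and lower numbers for stronger inhibition
compound 2 `CC(C)c1cccc(C(C)C)c1NC(=O)NS(=O)(=O)N1CCCC1` gives 15000 nM in this assay
compound 3 `CCCCN(C)S(=O)(=O)NC(=O)Nc1c(C(C)C)cccc1C(C)C` gives 2300 nM in this assay

Compound 2 holds the highest number of the three; the nearest is compound 1, separated by a 3.8-fold higher number from compound 1 to compound 2 (0.59 log units; beyond the scatter), and the furthest is compound 3, separated by a 6.5-fold lower number from compound 2 to compound 3 (0.81 log units; beyond the scatter). Compound 4 `C=CCN(CC)S(=O)(=O)NC(=O)Nc1c(C(C)C)cccc1C(C)C` has not been measured in this assay. Against compound 2 its change is allyl(ethyl)amino in place of pyrrolidin-1-yl on a sulfonyl sulfur.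

Two of the measured steps bear on this change. Both replace or introduce the pyrrolidin-1-yl ring against an acyclic amine on the same sulfur: the ring in place of dimethylamino gave a 3.8-fold higher number from compound 1 to compound 2 (0.59 log units; beyond the scatter), and butyl(methyl)amino in place of the ring gave a 6.5-fold lower number from compound 2 to compound 3 (0.81 log units; beyond the scatter). The step from dimethylamino to butyl(methyl)amino, a 1.7-fold lower number from compound 1 to compound 3 (0.23 log units; within the scatter), shows that lengthening the chain on the sulfonamide nitrogen mattered little among these compounds. Allyl(ethyl)amino is again an acyclic amine with a chain count close to that of compound 3, so a step beyond the scatter toward a lower number is expected for compound 4, estimated as a 6.0-fold lower number from compound 2 to compound 4 (0.78 log units; beyond the scatter). Compound 4 is therefore expected to give about 2500 nM in this assay, most likely between 1000 nM and 7000 nM.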

Compound 4, half-maximal inhibitory concentration: 2100 nM
Compound 4: the middle estimate sits 1.2-fold (0.08 log units) above what was measured, and the stated range covers the measured number.
By their numbers in this assay, from the lowest: compounds 4, 3 and 1 (each within the scatter of the next); then compound 2.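

In this assay, allyl(ethyl)amino in place of pyrrolidin-1-yl on the sulfonyl sulfur gives a 7.1-fold lower number from compound 2 to compound 4 (0.85 log units; beyond the scatter) and thereby adds a third acyclic amine to the side of the series apart from compound 2, so the gap to the ring no longer rests on dimethylamino and butyl(methyl)amino alone. Among the acyclic amines, a 1.1-fold lower number from compound 3 to compound 4 (0.04 log units; within the scatter) and a 1.9-fold lower number from compound 1 to compound 4 (0.27 log units; within the scatter) are the two steps that separate nothing, so in this assay a double bond outside aromatic rings and a change from dimethylamino to allyl(ethyl)amino come with no readable shift, and compound 2 remains the only compound shown that stands apart from the others. No measurement on hand accounts for the gap between the ring and the acyclic amines.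

Still open, on these data alone, is whether a piperidin-1-yl or a morpholin-4-yl group on the sulfonyl sulfur would stay with the pyrrolidin-1-yl ring or fall in with the acyclic amines. Equally open, as far as these compounds go, is whether a much longer chain on the sulfonamide nitrogen, such as octyl, or a benzyl group there would move the number out of the range these acyclic amines share.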